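The source may hold more compounds than are shown below. What is called first, only, known or untested is meant among the compounds shown, and "the series" means these compounds.

Compound 1, `CCCCCCNc1nc(SCc2ccc(C(F)(F)F)cc2)nc2ccccc12`, gives 24300 nM in a functional assay on MCF7 cells (Homo sapiens) for cytotoxicity, read by MTT assay, with a stated time of 72 h; on this read-out lower numbers stand for stronger inhibition and higher numbers for weaker inhibition. Compound 2, `COc1ccccc1Nc1nc(SCc2ccc(C(F)(F)F)cc2)nc2ccccc12`, gives in this assay only a limit, > 50000 nM. Compound 3, `FC(F)(F)c1ccc(CSc2nc(Nc3ccc(Cl)cc3)c3ccccc3n2)cc1`, gives 21500 nM in this assay.

Among the numbers shown in this assay, compound 3 sits at the low end, with compound 1 nearest: a 1.1-fold lower number from compound 1 to compound 3 (0.05 log units; within the scatter), a gap that lies within the scatter, so the two cannot be separated. The remaining value is a limit: the limit of > 50000 nM in this assay, at which 1 of the 3 values shown sits.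

Compound 4, `Cc1ccc(Nc2nc(SCc3ccc(C(F)(F)F)cc3)nc3ccccc23)cc1`, differs from compound 3 in one place: methyl in place of chloro on an aromatic carbon. Among the compounds with values here, no measured step alters a single small group on that ring; the steps that touch the amine substituent are larger swaps. a 1.1-fold lower number from compound 1 to compound 3 (0.05 log units; within the scatter) replaces a hexyl chain by the whole 4-chlorophenyl and remains within the scatter, whereas an at least 2.0-fold higher number from compound 1 to compound 2 (0.31 log units; beyond the scatter) and an at least 2.3-fold lower number from compound 2 to compound 3 (0.36 log units; beyond the scatter) both involve a 2-methoxyphenyl that reaches only a limit. Exchanging chloro for methyl on an aromatic carbon is a far smaller change than any of these, so no step beyond the scatter is expected in this assay.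

Compound 4 is therefore expected to give about 22000 nM in this assay, somewhere between 10000 nM and 50000 nM. The expected step is a 1.0-fold higher number from compound 3 to compound 4 (0.01 log units; within the scatter), which stays within the scatter.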

Compound 4, half-maximal inhibitory concentration: > 50000 nM
Compound 4 gave a limit, no number; the forecaster's own chance of this, stated with the estimate: 20%; middle value at least 2.2-fold (0.35 log units) from the limit.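

Earlier, only whole substituents on the amine nitrogen had been exchanged; this pair shows that in this assay the read-out also responds to one heavy atom on the aromatic carbon para to a large group, with an at least 2.3-fold higher number from compound 3 to compound 4 (0.36 log units; beyond the scatter). The aromatic ring on that nitrogen therefore does not settle the outcome by itself: a 1.1-fold lower number from compound 1 to compound 3 (0.05 log units; within the scatter), whereas an at least 2.0-fold higher number from compound 1 to compound 4 (0.31 log units; beyond the scatter), so hexyl can be matched by 4-chlorophenyl but not by 4-methylphenyl. Compound 4 gives a limit rather than a number, as compound 2 does, and the step between these two cannot be read: the limit of > 50000 nM in this assay, at which 2 of the 4 values shown sit.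

The compounds shown leave open whether fluoro, bromo or a nitrile on that same aromatic carbon would read like chloro or like methyl, and so whether chloro is unusual there or methyl is. They also leave open whether the exchange of chloro for methyl would give a similar step with a plain benzyl on the sulfur, in place of the group that all four compounds carry there.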